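Carbamate to urea at the aryl amide of compound 1

The source may report more compounds than this note shows. Statements on the series, on what has been measured and on what is new or still open speak of the compounds shown alone.

Within the data shown here, compound 1 `CCCOC(=O)Nc1ccc(S(=O)(=O)N2C[C@H](c3ccccc3)NC2=O)cc1CC` is the only member of the series with a numerical result in a functional assay on HCT-116 cells (Homo sapiens) for cytotoxicity, read by MTT assay; on this read-out lower numbers stand for stronger inhibition and higher numbers for weaker inhibition: compound 1 gives 60 nM. The other measured compound, compound 2 `Cc1cc(S(=O)(=O)N2C(=O)N[C@@H](c3ccccc3)C2C)ccc1NC(=O)c1ccc([N+](=O)[O-])cc1`, returns only a limit of this assay, > 10000 nM, and that sits at the limit of > 10000 nM in this assay, at which 1 of the 2 values shown sits; compound 2 shares no single-point relationship with compound 1, so its result says nothing direct about the step considered here.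

Compound 3 `CCc1cc(S(=O)(=O)N2C[C@H](c3ccccc3)NC2=O)ccc1NC(=O)NC(C)C` differs from compound 1 in one place: isopropylamino in place of propoxy on a carbonyl carbon. The chain length and heavy-atom count are kept, the oxygen of the propoxy group is replaced by the nitrogen of the isopropylamino group, and a hydrogen-bond donor enters where an acceptor leaves. Among the measured compounds shown here, no measured pair in this set probes such a carbamate-to-urea exchange, so there is no basis for expecting more than a small shift; the estimated step of a 1.5-fold higher number from compound 1 to compound 3 (0.18 log units; within the scatter) is taken to lie within the usual scatter of this assay, with a slight lean toward weaker inhibition. Compound 3 is therefore expected to give 90 nM, with a range from 25 nM to 350 nM.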

Compound 3, half-maximal inhibitory concentration: 60 nM
Estimate against measurement, compound 3: 1.5-fold (0.18 log units) above; low and high end bracket the measured number.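

In this assay, among these compounds, the exchange of propoxy for isopropylamino on the carbonyl carbon gives no change at the digits printed from compound 1 to compound 3 (within the scatter), and this is the only single-place step so far. At this position, then, the carbamate of compound 1 and the urea of compound 3 cannot be told apart on this read-out, even though a hydrogen-bond donor enters where an acceptor leaves; the finding extends only to this one pair and does not show that the position tolerates change in general. No measurement shown here offers a cause for this result.

Going by these compounds, whether a longer chain such as hexyloxy, a benzylamino group or a free amine on the same carbonyl carbon would keep the level of compound 1 remains open, as does the contribution of the carbonyl itself. Compound 2 gives > 10000 nM, which is a limit of the assay, and since it differs from compound 1 in more than one place it cannot be read against this step.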